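The source may hold more compounds than are shown below. What is called first, only, known or untested is meant among the compounds shown, and "the series" means these compounds.

Measured so far in a toxicity assay on HaCaT cells (Homo sapiens) for cytotoxicity, read by MTT assay; on this read-out higher numbers stand for weaker inhibition and lower numbers for stronger inhibition:

Compound 1 `Cc1ccc(-n2nc(-c3ccc(C(F)(F)F)cc3O)nc2-c2ccccc2O)cc1` gives 81800 nM
Compound 2 `CCc1ccc(-n2nc(-c3ccc(C(F)(F)F)cc3O)nc2-c2ccccc2O)cc1` gives 57000 nM

Only these two numbers are available, and compound 2, at 57000 nM in this assay, lies within the scatter of compound 1. Neither can therefore be ranked above the other. The next compound, compound 3 `CC(C)c1ccc(-n2nc(-c3ccc(C(F)(F)F)cc3O)nc2-c2ccccc2O)cc1`, extends the same substituent from 4-ethylphenyl to 4-isopropylphenyl. The change is methyl in place of hydrogen on a saturated chain carbon bound to an aromatic carbon and a saturated chain carbon.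

Going by the values given here, one measured step bears on this change, and it is a close relative rather than an exact match. It also placed a methyl in place of hydrogen on a saturated chain carbon bound to an aromatic carbon, and it amounted to a 1.4-fold lower number from compound 1 to compound 2 (0.16 log units; within the scatter) with no clear shift. On that single step, no change beyond the scatter is expected in this assay for the further methyl. The estimate corresponds to an expected 1.1-fold lower number from compound 2 to compound 3 (0.06 log units; within the scatter) for this added methyl. For compound 3 the expected value is 50000 nM in this assay with an estimated range from 25000 nM to 100000 nM for repeated measurements.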

Compound 3, half-maximal inhibitory concentration: 51400 nM
Estimate against measurement, compound 3: 1.0-fold (0.01 log units) below, within the range that was stated.
By their numbers in this assay, from the lowest: compounds 3, 2 and 1 (each within the scatter of the next).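

Extending the substituent from ethyl to isopropyl, with a methyl on a saturated chain carbon bound to an aromatic carbon and a saturated chain carbon, gives a 1.1-fold lower number from compound 2 to compound 3 (0.04 log units; within the scatter) in this assay and so leaves the number within the scatter. Read across the whole substituent, isopropyl in place of methyl on an aromatic carbon gives a 1.6-fold lower number from compound 1 to compound 3 (0.20 log units; within the scatter) and also stays within the scatter, so even the larger replacement, which the earlier pair could not test, does not separate compound 1 from compound 3 in this assay. No measurement at hand explains why these three compounds cannot be told apart.

From the compounds shown here alone, it remains open whether this flat picture would hold for a longer chain such as n-butyl, or whether a group of another kind in the same place, such as an amine or a carboxylic acid, would give a step beyond the scatter. The compounds shown also leave open what replacing the trifluoromethyl or either hydroxyl of the shared core would do in this assay, since all three compounds carry these groups unchanged.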